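The compounds below may be only part of what the source reports. "The series", "measured", "known", "first", "only" and "open" are said of these compounds alone.

Of the compounds shown here, three sharing one core have so far been measured in an assay on Huh-7 cells for agonist activity at Bile acid receptor (Homo sapiens), read by a luciferase reporter; a lower number here means that less compound is needed, a higher number that more compound is needed for the effect. Compound 1 `CCCn1c(-c2ccc(OCc3c(-c4c(Cl)cccc4Cl)noc3C(C)C)cc2)nc2ccc(C(=O)O)cc21` gives 9.3 nM, compound 2 `CCCC(CCC)n1c(-c2ccc(OCc3c(-c4c(Cl)cccc4Cl)noc3C(C)C)cc2)nc2ccc(C(=O)O)cc21` gives 1.8 nM, and compound 3 `CC(C)c1onc(-c2c(Cl)cccc2Cl)c1COc1ccc(-c2nc3ccc(C(=O)O)cc3n2-c2ccc(F)cc2)cc1` gives 32.2 nM. Among these three, compound 3 stands at the highest number, so it needs the most compound for the effect; its nearest neighbour is compound 1, and compound 2 sits furthest from it.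

The next compound, compound 4 `CC(C)c1onc(-c2c(Cl)cccc2Cl)c1COc1ccc(-c2nc3ccc(C(=O)O)cc3n2CC2CCCCC2)cc1`, differs from compound 3 in only one place: cyclohexylmethyl in place of 4-fluorophenyl on an aromatic nitrogen. The group that enters is built of carbon only, with no aromatic ring.

Going by the values given here, two measured steps bear directly on this change, since both concern the same position. Moving from a short chain to the 4-fluorophenyl group gave a 3.5-fold higher number from compound 1 to compound 3 (0.54 log units; beyond the scatter), and moving from the larger branched chain to the same group gave an 18-fold higher number from compound 2 to compound 3 (1.25 log units; beyond the scatter). In both cases replacing a saturated carbon group by the aromatic one raised the number. Reversing that direction, from the aromatic group to a saturated one of similar size, is therefore expected to lower the number; for compound 4 the expected step is a 9.2-fold lower number from compound 3 to compound 4 (0.96 log units; beyond the scatter). The estimate for compound 4 in this assay is 3.5 nM, with a likely range from 1.2 nM to 12 nM.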

Compound 4, half-maximal effective concentration: 0.52 nM
Estimate against measurement, compound 4: 6.7-fold (0.83 log units) above; the measured number lies below the stated range.
By their numbers in this assay, from the lowest: compound 4; then compound 2; then compound 1; then compound 3.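

In this assay, the step from the 4-fluorophenyl group to the cyclohexylmethyl group, which has the same count of heavy atoms, gives a 62-fold lower number from compound 3 to compound 4 (1.79 log units; beyond the scatter), so two groups that each hold one six-membered ring are far from interchangeable on this aromatic nitrogen. The cyclohexylmethyl group also outdoes both open chains, with a 3.5-fold lower number from compound 2 to compound 4 (0.54 log units; beyond the scatter) and an 18-fold lower number from compound 1 to compound 4 (1.25 log units; beyond the scatter), which shows that the saturated carbon groups differ clearly among themselves and that the branched 1-propylbutyl chain does not give the lowest number at this position. No measurement shown here accounts for these differences.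

The step from compound 3 to compound 4 removes the fluorine, replaces the aromatic ring with a non-aromatic one and adds a carbon between the ring and the nitrogen, so the compounds shown cannot say which of these changes matters. A benzyl group, which keeps an aromatic ring with that extra carbon, and a cyclohexyl group bound straight to the nitrogen, which keeps the saturated ring without it, would begin to separate these changes.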